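Swapping the aryl group on a urea nitrogen

This account rests on a few compounds, and the source may have more. Where it says the series, first, only, none or still open, it means among the compounds named here.

Compounds measured in a functional assay on MGC-803 cells (Homo sapiens) for antiproliferative activity, read by MTT assay, with a stated time of 48 h; on this read-out lower numbers stand for stronger inhibition and higher numbers for weaker inhibition:
compound 1 `Cc1ccc(NC(=O)Nc2cccc(CNc3nccnc3Cl)c2)cc1C` gives 9870 nM
compound 2 `O=C(Nc1cccc(CNc2nccnc2Cl)c1)Nc1ccccc1Cl` gives 7130 nM
compound 3 `CCc1ccc(NC(=O)Nc2cccc(CNc3nccnc3Cl)c2)c(CC)c1` gives 6130 nM

Compound 1 has the highest of the three numbers in this assay, but its nearest neighbour is compound 2, and that step is a 1.4-fold lower number from compound 1 to compound 2 (0.14 log units; within the scatter), within the scatter; compound 3 also lies within the scatter of compound 1. Compound 4 `CCc1ccccc1NC(=O)Nc1cccc(CNc2nccnc2Cl)c1` differs from compound 1 in one place: 2-ethylphenyl in place of 3,4-dimethylphenyl on an amide-type nitrogen. Within the data shown here, the one step that bears on this change is a 1.4-fold lower number from compound 1 to compound 2 (0.14 log units; within the scatter), where another aryl group replaced the same group on the same nitrogen, and it stayed within the scatter. Compound 4 is therefore expected to show no step beyond the scatter, that is a 1.3-fold lower number from compound 1 to compound 4 (0.12 log units; within the scatter). Compound 4 is estimated at 7500 nM, with a range from 3500 nM to 16000 nM.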

Compound 4, half-maximal inhibitory concentration: 9370 nM
Compound 4: the middle estimate sits 1.2-fold (0.10 log units) below what was measured, within the range that was stated.
By their numbers in this assay, from the lowest: compounds 3, 2, 4 and 1 (each within the scatter of the next).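

On this amide-type nitrogen, 2-ethylphenyl in place of 3,4-dimethylphenyl gives no step beyond the scatter (a 1.1-fold lower number from compound 1 to compound 4 (0.02 log units; within the scatter)). The two other one-place changes also stay within it: hydrogen in place of ethyl (a 1.5-fold higher number from compound 3 to compound 4 (0.18 log units; within the scatter)) and ethyl in place of chloro (a 1.3-fold higher number from compound 2 to compound 4 (0.12 log units; within the scatter)), so these four aryl groups cannot be told apart here. No measured evidence is available to explain these numbers. From the compounds shown here alone, it remains open whether an amine or a carboxylic acid on this aryl ring would give a step beyond the scatter.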